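The compounds below may be only part of what the source reports. "The series", "measured", "known", "first", "only" and "open" are said of these compounds alone.

Of the compounds shown here, three built on one shared core have been tested in a functional assay on A549 cells (Homo sapiens) for antiproliferative activity, read by MTT assay, with a stated time of 72 h; on this read-out lower numbers stand for stronger inhibition and higher numbers for weaker inhibition. Compound 1 `COc1cc(F)c(NC(=O)c2ccnc(O)c2)cc1Nc1nccc(-c2cn(C)c3ccccc23)n1` gives 11700 nM. Compound 2 `COc1cc(F)c(NC(=O)c2ncccn2)cc1Nc1nccc(-c2cn(C)c3ccccc23)n1` gives 8400 nM. That step is a 1.4-fold lower number from compound 1 to compound 2 (0.14 log units; within the scatter). Compound 3 `COc1cc(N(C)CCN(C)C)c(NC(=O)c2ccnc(O)c2)cc1Nc1nccc(-c2cn(C)c3ccccc23)n1` gives 11200 nM. That step is a 1.0-fold lower number from compound 1 to compound 3 (0.02 log units; within the scatter). Compound 3 thus stands second highest of the three numbers, but all three lie within the scatter of one another, so none of them can be called stronger or weaker than the rest.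

Compound 4 `COc1cc(N(C)CCN(C)C)c(NC(=O)c2cnccn2)cc1Nc1nccc(-c2cn(C)c3ccccc23)n1` differs from compound 3 in one place: pyrazin-2-yl in place of 2-hydroxypyridin-4-yl on a carbonyl carbon. Going by the values given here, the only measured step that bears on this is a 1.4-fold lower number from compound 1 to compound 2 (0.14 log units; within the scatter), where pyrimidin-2-yl took the place of the same 2-hydroxypyridin-4-yl on the carbonyl carbon. Pyrazin-2-yl is not pyrimidin-2-yl, yet it is likewise a six-membered aromatic ring with two hetero atoms and no hydrogen-bond donor, and the earlier exchange stayed within the scatter. The step expected in this assay is therefore a 1.3-fold lower number from compound 3 to compound 4 (0.12 log units; within the scatter), nothing beyond the scatter. Compound 4 is estimated at 8500 nM, with a likely range from 3500 nM to 20000 nM.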

Compound 4, half-maximal inhibitory concentration: 4330 nM
Compound 4: the middle estimate sits 2.0-fold (0.29 log units) above what was measured; the range from low to high includes it.
By their numbers in this assay, from the lowest: compounds 4, 2, 3 and 1 (each within the scatter of the next, the first and the last beyond it).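

In this assay, the change on this carbonyl carbon now gives a 2.6-fold lower number from compound 3 to compound 4 (0.41 log units; beyond the scatter), the only step at this position shown here that lies beyond the scatter, whereas a 1.4-fold lower number from compound 1 to compound 2 (0.14 log units; within the scatter) stayed within it. So, with (2-(dimethylamino)ethyl)(methyl)amino on the aromatic carbon, replacing 2-hydroxypyridin-4-yl with pyrazin-2-yl, a ring with two hetero atoms and no hydrogen-bond donor, brings a modest but readable strengthening of the antiproliferative effect. Nothing available explains this step, so the counted differences between the two rings remain a description and not a cause.

From the compounds shown here alone, the two steps differ in the entering ring and in the group on the aromatic carbon, so it remains open whether pyrazin-2-yl would give the same step with fluoro on that carbon, or pyrimidin-2-yl with the (2-(dimethylamino)ethyl)(methyl)amino group. Going by these compounds, it also remains open how a plain phenyl ring or a pyridin-2-yl ring would compare with pyrazin-2-yl on the same carbonyl carbon.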